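The source may report more compounds than this note shows. Statements on the series, on what has been measured and on what is new or still open speak of the compounds shown alone.

Of the compounds shown here, three have been tested in a functional assay on ML1 cells (Homo sapiens) for antiproliferative activity, read by WST assay, with a stated time of 3 days; a higher number here means a weaker inhibitor, a lower number a stronger inhibitor. Compound 1 (`N#Cc1cc(=O)[nH]c(=O)n1[C@@H]1O[C@H](CO)[C@@H](O)[C@H]1O`) gives > 50000 nM, which is a limit of the assay and not a number. Compound 2 (`[N-]=[N+]=Nc1cc(=O)[nH]c(=O)n1[C@@H]1O[C@H](CO)[C@@H](O)[C@H]1O`) gives > 50000 nM, again only a limit. Between these two, azido in place of cyano on an aromatic carbon yields a step that the two limits leave unreadable from compound 1 to compound 2. Going by the values given here, compound 3 (`[N-]=[N+]=Nc1c(F)c(=O)[nH]c(=O)n1[C@@H]1O[C@H](CO)[C@@H](O)[C@H]1O`) gives 600 nM, the only true number. With fluoro in place of hydrogen on an aromatic carbon, the data show an at least 83-fold lower number from compound 2 to compound 3 (1.92 log units; beyond the scatter).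

Compound 4 (`CCc1c(F)c(=O)[nH]c(=O)n1[C@@H]1O[C@H](CO)[C@@H](O)[C@H]1O`) keeps that fluoro group but carries ethyl in place of azido on an aromatic carbon. Among the compounds with values here, no measured step makes this exchange. Within the data shown here, the nearest is the unreadable change at the same carbon, and the only sizeable step, an at least 83-fold lower number from compound 2 to compound 3 (1.92 log units; beyond the scatter), shows that one small change can separate a measurable compound from an inactive one. A clear loss in this assay is therefore expected, towards a weaker inhibitor. The estimated step is a 33-fold higher number from compound 3 to compound 4 (1.52 log units; beyond the scatter). For compound 4 the estimated value is 20000 nM, with an expected range of 3000 nM to 50000 nM.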

Compound 4, half-maximal inhibitory concentration: 2100 nM
Compound 4: middle estimate off by 9.5-fold (0.98 log units), on the high side, and the stated range ends above it.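

In this assay, going by these compounds alone, the step with ethyl in place of azido, with the fluoro group kept, is a 3.5-fold higher number from compound 3 to compound 4 (0.54 log units; beyond the scatter), and it is the first readable step at this carbon. It shows that azido is not needed for a true number here: azido, which carries a hydrogen-bond acceptor, gives way to ethyl, which carries none, and the value stays well clear of the limit. Within the data shown here, the earlier compounds could not show this, as the only earlier exchange at this carbon had no fluoro group and could not be read: the limit of > 50000 nM in this assay, at which 2 of the 4 values shown sit.

The compounds shown leave open whether ethyl would keep a true number with hydrogen in place of the fluoro group. They also leave open how an amine, a carboxylic acid or a longer chain would behave on this carbon.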